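The source may report more compounds than this note shows. Statements on the series, on what has been measured and on what is new or still open speak of the compounds shown alone.

Measured compounds in the series:

Compound 1, `C=CCn1c(SCC(=O)c2ccccc2)nnc1-c1ccccc1`, in a functional assay on the whole organism (strain albino) for inhibition, with Rattus norvegicus as the target, read by paw edema, with a stated time of 4 h, at a dose of 0.28 mmol/kg by the oral route (on this read-out lower numbers stand for less inhibition and higher numbers for more inhibition at the one dose given (going by the name of the read-out)), compound 1 gives 66%.
Compound 2, `CCn1c(SCC(=O)c2ccccc2)nnc1-c1ccccc1`, in this assay compound 2 gives 63%.
Compound 3, `CCn1c(SC/C(=N/O)c2ccccc2)nnc1-c1cc(OC)c(OC)c(OC)c1`, in this assay compound 3 gives 79%.

Compounds 1 and 2 share one core and differ in a single place, (vinyl in place of methyl on a saturated chain carbon bound to an aromatic nitrogen). The step is a number 3 percentage points higher from compound 2 to compound 1 (within the scatter), so the two values are not separated in this assay. Compound 3 carries a different core; the difference between the two cores is not broken down here. In this assay compound 3 stands highest of the three, and its gaps to compound 1 and to compound 2 both lie beyond the scatter.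

Compound 4, `C=CCn1c(SC/C(=N/O)c2ccccc2)nnc1-c1cc(OC)c(OC)c(OC)c1`, is not yet measured. It differs from compound 3 by vinyl in place of methyl on a saturated chain carbon bound to an aromatic nitrogen, the same change as from compound 2 to compound 1, at the same place. On these data alone, since that change gave a step within the scatter, the expected step from compound 3 to compound 4 is a number 1 percentage points higher from compound 3 to compound 4 (within the scatter), resting on a number 3 percentage points higher from compound 2 to compound 1 (within the scatter) alone; whether the change reads the same on the core of compound 3 is untested. The estimate for compound 4 in this assay is 80%, expected between 68% and 90%.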

Compound 4, a percentage reported as inhibition, in the whole organism at one dose (the size of the read-out at that dose, not a potency): 73%
For compound 4 the middle estimate is 7 percentage points above the measured one; the measured number falls inside the stated range.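

On the core of compound 3, vinyl in place of methyl on a saturated chain carbon bound to an aromatic nitrogen (ethyl to allyl, read one bond further out) gives a number 6 percentage points lower from compound 3 to compound 4 (within the scatter) in this assay. Set beside the same change on the core of compound 1, the two steps cannot be told apart, so the change carries across these two cores without a separable difference: the same change on two cores in this assay, a number 3 percentage points higher (within the scatter) from compound 2 to compound 1 and a number 6 percentage points lower (within the scatter) from compound 3 to compound 4, 9 percentage points apart, within the scatter of two such steps. Among these compounds, this does not show that the change has no effect or that it would read the same on any further core, since the evidence is only two pairs at a single dose, and a small effect or a small dependence on the core could lie hidden in the scatter.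

The compounds shown leave open how a longer chain, such as propyl or butyl, or a benzyl group would read at this place. They also leave open whether a chain ending in an amine or a carboxylic acid would move the inhibition of paw edema beyond the scatter.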